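The source may report more compounds than this note shows. Statements on the series, on what has been measured and on what is new or still open speak of the compounds shown alone.

In a functional assay on cells (Platelet, Homo sapiens) for inhibition (a higher number here means a weaker inhibitor, a lower number a stronger inhibitor), compound 1 (`CCOC(=O)c1cccc(-c2n[nH]c3ccccc23)c1`) gives > 10000 nM, which is a limit of the assay and not a number. Compound 3 (`CCOC(=O)c1cccc(-c2nn(Cc3ccccc3)c3ccccc23)c1`) gives > 10000 nM, again a limit. Compound 2 (`CCOC(=O)c1ccc(-c2nn(Cc3ccc(F)cc3)c3ccccc23)cc1`) gives > 10000 nM, and this too is a limit, so compound 2 has no numerical position in this assay. What the series shows so far is the limit of > 10000 nM in this assay, at which 3 of the 3 values shown sit.

The next compound, compound 4 (`CCOC(=O)c1ccc(-c2nn(Cc3cccnc3)c3ccccc23)cc1`), differs from compound 2 in one place, with pyridin-3-yl in place of 4-fluorophenyl on a saturated chain carbon bound to an aromatic nitrogen. In other words, 4-fluorobenzyl gives way to (pyridin-3-yl)methyl.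

For the measured compounds named here, the only measured step is a step that the two limits leave unreadable from compound 1 to compound 3. It concerns benzyl in place of hydrogen on an aromatic nitrogen, and it gives no size to carry over to this change. Going by the values given here, no measured step compares these two groups directly. The expectation therefore stays close to the limit held by compound 2, with no direction favoured in this assay. The expected step, a number no higher from compound 2 to compound 4 (the limit leaves the size open), is not expected to be readable beyond the scatter. A further limit is the most likely report, and the estimate for compound 4 is 10000 nM, with an expected range of 3000 nM to 30000 nM.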

Compound 4, half-maximal inhibitory concentration: > 10000 nM
Compound 4: only a limit was reported; the forecaster's own chance of this, stated with the estimate: 75%; the middle value sits exactly at the limit.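

In this assay compound 4 gives > 10000 nM, which is a limit of the assay and not a number, and compound 2 also stands at a limit, so no step can be read between the two. The compounds shown leave open which structure, if any, would give a readable number, for the series offers only this: the limit of > 10000 nM in this assay, at which 4 of the 4 values shown sit.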